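The compounds below may be only part of what the source reports. "The series", "measured", "known", "first", "only" and "open" are said of these compounds alone.

Measured so far:
- compound 1 `CC(C)(C)OC(=O)NCCS(=O)(=O)NC(=O)c1ccc(Nc2nc(NC3(c4ccc(Cl)cc4)CC3)nc(OCC(F)(F)F)n2)cc1`: 92%
- compound 2 `CC(C)C(=O)NCCS(=O)(=O)NC(=O)c1ccc(Nc2nc(NC3(c4ccc(Cl)cc4)CC3)nc(OCC(F)(F)F)n2)cc1`: 86%
- compound 3 `CC(C)NC(=O)NCCS(=O)(=O)NC(=O)c1ccc(Nc2nc(NC3(c4ccc(Cl)cc4)CC3)nc(OCC(F)(F)F)n2)cc1`: 100%

In an ADME assay on microsomes from liver (Homo sapiens) for metabolic stability, with a stated time of 10 min (a lower number here means that less of the compound is left, a higher number that more of the compound is left), compound 3 stands at the top of the three numbers. Its separation from compound 1 is a number 8 percentage points higher from compound 1 to compound 3 (within the scatter), which stays within the scatter, whereas a number 14 percentage points higher from compound 2 to compound 3 (beyond the scatter) lies beyond it, though only modestly. Compound 4 `CN(C)S(=O)(=O)NC(=O)c1ccc(Nc2nc(NC3(c4ccc(Cl)cc4)CC3)nc(OCC(F)(F)F)n2)cc1` differs from compound 3 in one place: dimethylamino in place of 2-((isopropylcarbamoyl)amino)ethyl on a sulfonyl sulfur. Among the measured compounds shown here, none of the measured steps touches this position; all three of them, a number 6 percentage points lower from compound 1 to compound 2 (within the scatter), a number 8 percentage points higher from compound 1 to compound 3 (within the scatter) and a number 14 percentage points higher from compound 2 to compound 3 (beyond the scatter), vary the carbonyl carbon of the chain and leave the sulfonyl sulfur unchanged. They bear on the new step only indirectly, in that every variant of the chain so far has kept the remaining fraction high. On that footing a step of about a number 10 percentage points lower from compound 3 to compound 4 (within the scatter) is expected, with no clear direction beyond the scatter. Compound 4 is therefore estimated at 90%, within a range from 72% to 100%.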

Compound 4, percent of the compound remaining: 86%
Compound 4: the middle estimate sits 4 percentage points above what was measured; the measured number falls inside the stated range.
By their numbers in this assay, from the lowest: compounds 2, 4, 1 and 3 (each within the scatter of the next, the first and the last beyond it).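

In this assay the exchange of the chain on the sulfonyl sulfur for dimethylamino gives a number 14 percentage points lower from compound 3 to compound 4 (beyond the scatter) while the same group gives no change at the digits printed from compound 2 to compound 4 (within the scatter) and a number 6 percentage points lower from compound 1 to compound 4 (within the scatter) when it replaces the other two chains. This change at the sulfonyl sulfur itself shows that only the 2-((isopropylcarbamoyl)amino)ethyl chain stands apart from dimethylamino beyond the scatter, and that compound 4 keeps 86% of the compound without any of these chains. Nothing available accounts for that difference between the chains.

The compounds shown leave open how a methyl group, a morpholine or a chain ending in a carboxylic acid would read on the sulfonyl sulfur. They also leave open whether a longer chain carrying the same isopropylcarbamoyl end would match compound 3.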